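This account rests on a few compounds, and the source may have more. Where it says the series, first, only, none or still open, it means among the compounds named here.

Compound 1 `CCc1cccc2c(=O)c(-c3nn[nH]n3)c[nH]c12`: > 25 mg/kg
Compound 2 `CSc1cccc2c(=O)c(-c3nn[nH]n3)c[nH]c12`: 25 mg/kg

Of the compounds shown here, two built on one shared core have been tested in a functional assay on the whole organism (strain Sprague-Dawley) for inhibition, with Rattus norvegicus as the target; a lower number here means that less compound is needed, a higher number that more compound is needed for the effect. Compound 1 `CCc1cccc2c(=O)c(-c3nn[nH]n3)c[nH]c12` carries an ethyl group on an aromatic carbon; in this assay compound 1 reaches only a limit of the assay, > 25 mg/kg. Compound 2 `CSc1cccc2c(=O)c(-c3nn[nH]n3)c[nH]c12` carries a methylsulfanyl group at the same place, and in this assay compound 2 gives 25 mg/kg. Compound 2 thus holds the only number shown. The value of compound 1 is a limit. For the measured compounds named here, the one measured step, a number no higher from compound 1 to compound 2 (the limit leaves the size open), has a size that cannot be read because one end sits at the limit (the limit of > 25 mg/kg in this assay, at which 1 of the 2 values shown sits).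

Compound 3 `Cc1cccc2c(=O)c(-c3nn[nH]n3)c[nH]c12` is the next step: methyl in place of methylsulfanyl on an aromatic carbon. Going by the values given here, no measured step swaps methylsulfanyl for methyl, so the step from compound 1 to compound 2 is only a loose guide: swapping one small group on that carbon for another moved the read-out from a limit to a number. For compound 3 the expected change is no change at the digits printed from compound 2 to compound 3 (within the scatter), that is, nothing beyond the usual scatter. The estimate for compound 3 is 25 mg/kg, with a range from 10 mg/kg to 60 mg/kg, and a fair chance that compound 3 returns only a limit.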

Compound 3, minimum effective dose: > 10 mg/kg
Compound 3 ended at the assay's limit; the forecaster's own chance of this, stated with the estimate: 40%; the middle value does not contradict the limit.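

In this assay compound 3 gives > 10 mg/kg, which is a limit of the assay. The steps joining compound 3 to compound 2 and to compound 1 cannot be read. The compounds shown leave open how far methyl, ethyl and methylsulfanyl on this aromatic carbon truly differ in the dose needed, with only compound 2 holding an actual number.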